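A few compounds are considered here, and "the series" means these few. Any claim that something is new, unique, unknown or untested is made for them only; others in the source may bear on it.

Compounds measured in a functional assay on A549 cells (Homo sapiens) for cytotoxicity, read by MTT assay, with a stated time of 48 h; a lower number here means a stronger inhibitor, a higher number a weaker inhibitor:
compound 1, `CCN(CC)c1ccc2cc(C(=O)c3ccc(N4CCN(C(=O)CN5CCNCC5)CC4)cc3)oc2c1`, 320 nM
compound 2, `CCN(CC)c1ccc2cc(C(=O)c3ccc(N4CCN(C(=O)CN5CCN(C(=O)/C=C/c6ccccc6)CC5)CC4)cc3)oc2c1`, 9450 nM
compound 3, `CCN(CC)c1ccc2cc(C(=O)c3ccc(N4CCN(C(=O)CN5CCN(S(=O)(=O)c6ccc(C(F)(F)F)cc6)CC5)CC4)cc3)oc2c1`, > 40000 nM

Compound 3 returns no number in this assay but only a limit, (the limit of > 40000 nM in this assay, at which 1 of the 3 values shown sits). Going by the values given here, the single measured step, a 30-fold higher number from compound 1 to compound 2 (1.47 log units; beyond the scatter), concerns a different part of the molecule and does not cover the change considered here. Compound 4, `CCN(CC)c1ccc2cc(C(=O)c3ccc(N4CCN(C(=O)CN5CCN(S(=O)(=O)c6ccc(F)cc6)CC5)CC4)cc3)oc2c1`, differs from compound 3 by fluoro in place of trifluoromethyl on an aromatic carbon. Among the compounds with values here, no measured pair shows such an exchange on that aromatic ring, so its effect is not known from the data. Since compound 3 sits at a limit, compound 4 is expected to stay weak in this assay, and the estimated step of an at least 1.3-fold lower number from compound 3 to compound 4 (0.12 log units; that floor lies within the scatter) carries wide uncertainty. Compound 4 is estimated at 30000 nM, between 8000 nM and 120000 nM.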

Compound 4, half-maximal inhibitory concentration: 33200 nM
For compound 4 the middle estimate is 1.1-fold (0.04 log units) below the measured one; measured number inside the range.
By their numbers in this assay, from the lowest: compound 1; then compound 2; then compound 4. At a limit, above all of these: compound 3.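

Fluoro in place of trifluoromethyl on the aromatic carbon gives an at least 1.2-fold lower number from compound 3 to compound 4 (0.08 log units; that floor lies within the scatter) and so shows no clear gain from this exchange. Compound 3 gives a limit and not a number: the limit of > 40000 nM in this assay, at which 1 of the 4 values shown sits. In this assay the (4-fluorophenyl)sulfonyl group on the amine nitrogen gives a 100-fold higher number from compound 1 to compound 4 (2.02 log units; beyond the scatter) against hydrogen, and a 3.5-fold higher number from compound 2 to compound 4 (0.55 log units; beyond the scatter) against (2-phenylethenyl)carbonyl, so this sulfonyl group reads weaker than either.

Still open, going by these compounds, is how a methoxy or an amine on that aromatic carbon would read in this assay and whether a simple acetyl on the amine nitrogen would stay close to compound 1.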